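Swapping the Indole for a Fluoromethoxyphenyl

This account rests on a few compounds, and the source may have more. Where it says the series, first, only, none or still open, it means among the compounds named here.

Compound 1 `COc1cc(-c2ccnc3cc(-c4c[nH]c5ccccc45)nn23)cc(OC)c1OC` carries a 1H-indol-3-yl group on its shared core. In a functional assay on HeLa cells (Homo sapiens) for inhibition, read by CCK-8 assay, with a stated time of 48 h (on this read-out lower numbers stand for stronger inhibition and higher numbers for weaker inhibition), compound 1 gives 195 nM, the lowest of the two numbers recorded so far; the nearest is compound 2 `COc1cc(-c2ccnc3cc(-c4cccc(C)c4)nn23)cc(OC)c1OC`, which in this assay gives 4230 nM. That pair shows one step: a 22-fold higher number from compound 1 to compound 2 (1.34 log units; beyond the scatter). Compound 3 `COc1ccc(-c2cc3nccc(-c4cc(OC)c(OC)c(OC)c4)n3n2)cc1F` is not yet measured and differs from compound 1 in one place: 3-fluoro-4-methoxyphenyl in place of 1H-indol-3-yl on an aromatic carbon. The step from compound 1 to compound 2 bears directly on this change: there too a six-membered aromatic ring of carbon only took the place of the 1H-indol-3-yl, and the number rose far beyond the scatter. A rise of comparable size is therefore expected here, a 13-fold higher number from compound 1 to compound 3 (1.11 log units; beyond the scatter). For compound 3 the estimated value in this assay is 2500 nM, with a range from 800 nM to 8000 nM.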

Compound 3, half-maximal inhibitory concentration: 236 nM
The estimate for compound 3 lay 11-fold (1.03 log units) above the measured number, and the stated range ends above it.
By their numbers in this assay, from the lowest: compounds 1 and 3 (each within the scatter of the next); then compound 2.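

In this assay the change from 1H-indol-3-yl to 3-fluoro-4-methoxyphenyl gives a 1.2-fold higher number from compound 1 to compound 3 (0.08 log units; within the scatter) and so leaves no difference that can be read between the two groups at this position. The indole with its two rings and its hydrogen-bond donor is therefore not needed here for a low number, as a single six-membered aromatic ring of carbon only can match it. What that ring carries clearly counts, as the comparison of the two such rings gives an 18-fold lower number from compound 2 to compound 3 (1.25 log units; beyond the scatter) and shows that compound 2 did not speak for every group of this kind, though no data at hand explain the gap. Still open, as far as these compounds go, is whether the fluorine, the methoxy or the two together set compound 3 apart from compound 2. Also open, from the compounds shown here alone, is how a ring bearing an amine or a carboxylic acid would behave at this position.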